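Bromo for Methoxy on Two Xanthine Cores

This account rests on a few compounds, and the source may have more. Where it says the series, first, only, none or still open, it means among the compounds named here.

Compound 1 `COc1ccc(OCc2nc3c(c(=O)n(C)c(=O)n3C)n2C)cc1` gives 4670 nM in an assay on brain cells (strain Sprague-Dawley) for displacement of a labelled ligand from adenosine receptor A1 (Rattus norvegicus), read by scintillation counting, with a stated time of 60 min; on this read-out lower numbers stand for stronger inhibition and higher numbers for weaker inhibition.
Compound 2 `CCn1c(=O)c2c(nc(COc3ccc(OC)cc3)n2C)n(CC)c1=O` gives 1220 nM in this assay.
Compound 3 `Cn1c(=O)c2c(nc(COc3ccc(Br)cc3)n2C)n(C)c1=O` gives 3690 nM in this assay.

Three measured compounds share a common arrangement in which a substituted phenoxymethyl group hangs from a xanthine-like core. Compound 1 and compound 3 carry the core of compound 1; compound 2 carries a core with longer alkyl groups, and the difference between the two cores is not broken down here. Compound 2 stands with the lowest number of the three in this assay, and its distance from both compound 3 and compound 1 lies beyond the scatter.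

The change from compound 1 to compound 3 is bromo in place of methoxy on an aromatic carbon. It moved the read-out by a 1.3-fold lower number from compound 1 to compound 3 (0.10 log units; within the scatter), a shift that stays within the scatter, so the two values can be read as equal.

Compound 4 `CCn1c(=O)c2c(nc(COc3ccc(Br)cc3)n2C)n(CC)c1=O` is not yet measured. It differs from compound 2 by bromo in place of methoxy on an aromatic carbon; the place descriptions match word for word, so this is the same change as that from compound 1 to compound 3.

Because the earlier step of a 1.3-fold lower number from compound 1 to compound 3 (0.10 log units; within the scatter) was within the scatter, compound 4 is expected to move from compound 2 by about a 1.2-fold lower number from compound 2 to compound 4 (0.09 log units; within the scatter). Compound 4 is therefore estimated at 1000 nM in this assay, with a range from 400 nM to 2500 nM.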

Compound 4, inhibition constant: 264 nM
Estimate against measurement, compound 4: 3.8-fold (0.58 log units) above, and the stated range ends above it.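

In this assay, bromo in place of methoxy on the core of compound 2 gave a 4.6-fold lower number from compound 2 to compound 4 (0.66 log units; beyond the scatter), so on this core the change produced a real shift towards a lower number. Set beside the earlier pair, the result shows that the step did not carry over unchanged from one core to the other: the same change on two cores in this assay, a 1.3-fold lower number (0.10 log units; within the scatter) from compound 1 to compound 3 and a 4.6-fold lower number (0.66 log units; beyond the scatter) from compound 2 to compound 4, 3.7-fold (0.56 log units) apart, beyond the scatter of two such steps The comparison rests on only one pair per core, however, and the two cores differ by their alkyl groups as a whole, so it shows that the size of this step depended on the core in these four compounds, but not which part of the core matters, why the steps differ, or whether the same would hold on any further core.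

The compounds shown leave open how other groups at this place, such as chloro, a nitrile or a carboxylic acid, would read on either core. They also leave open whether a longer chain on the core, such as propyl, would bring a still larger step for 4-methoxyphenyl to 4-bromophenyl, or whether the gap between the two steps stops growing beyond the core of compound 2.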